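From 2-nitrophenyl to 4-nitrophenyl on a sulfonyl sulfur

The source may report more compounds than this note shows. Statements on the series, on what has been measured and on what is new or still open speak of the compounds shown alone.

Within the data shown here, in a functional assay on MDA-MB-231 cells (Homo sapiens) for cytotoxicity, read by sulforhodamine B assay, with a stated time of 3 days (on this read-out higher numbers stand for weaker inhibition and lower numbers for stronger inhibition), compound 1 (`O=[N+]([O-])c1ccc(S(=O)(=O)N2C[C@H](n3cnc4c(Cl)nc(Cl)nc43)OCc3ccccc32)cc1`) gives 110 nM and compound 2 (`O=[N+]([O-])c1ccccc1S(=O)(=O)N1CC(n2cnc3c(Cl)nc(Cl)nc32)OCc2ccccc21`) gives 280 nM as the only numbers so far. Compound 2 thus has the higher of the two numbers, meaning weaker inhibition, and its gap to compound 1 lies beyond the usual scatter of repeated measurements.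

Compound 3 (`O=[N+]([O-])c1ccc(S(=O)(=O)N2CC(n3cnc4c(Cl)nc(Cl)nc43)OCc3ccccc32)cc1`) has not yet been measured. It differs from compound 2 in one place, with 4-nitrophenyl in place of 2-nitrophenyl on a sulfonyl sulfur and the same atoms joined differently. Among the measured compounds shown here, no measured pair shows this change on its own, so any prediction is a judgement. Compound 1 also carries 4-nitrophenyl on its sulfonyl sulfur and gives 110 nM in this assay, so a moderate step towards a lower number is expected, only slightly beyond the scatter. Put as a step, the expected change is a 2.2-fold lower number from compound 2 to compound 3 (0.33 log units; beyond the scatter) on this evidence. For compound 3 the estimated value is 130 nM with an expected range from 60 nM to 280 nM in this estimate.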

Compound 3, half-maximal inhibitory concentration: 166 nM
Beside the measured number, compound 3's estimate is 1.3-fold (0.11 log units) below it, and the stated range covers the measured number.
By their numbers in this assay, from the lowest: compounds 1, 3 and 2 (each within the scatter of the next, the first and the last beyond it).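

On its own, 4-nitrophenyl in place of 2-nitrophenyl on a sulfonyl sulfur gives in this assay a 1.7-fold lower number from compound 2 to compound 3 (0.23 log units; within the scatter) and so leaves this pair no further apart than repeat measurements of one compound can lie. Among these compounds, compound 1 and compound 2 differ in more than one place, so only this new pair shows the nitrophenyl change by itself, and at this position the change alone has no effect that can be told from the scatter. The other new pair gives a 1.5-fold higher number from compound 1 to compound 3 (0.18 log units; within the scatter) and the single point that separates its two members, also without a gap beyond the scatter, is this: the fact that one of compounds 1 and 3 is drawn with a defined configuration and the other without, at the place where they differ.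

The drawing of compound 3 does not say which spatial forms the sample contains, so the compounds shown leave open how a form with the opposite configuration to compound 1 would read in this assay. Going by these compounds, all three compounds carry a nitrophenyl group on the sulfonyl sulfur, so it also stays open how an aminophenyl or a carboxyphenyl group at that place would read.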